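A few compounds are considered here, and "the series" means these few. Any claim that something is new, unique, unknown or untested is made for them only; others in the source may bear on it.

Of the compounds shown here, three on the shared core have been measured so far. In a functional assay on Caco-2 cells (Homo sapiens) for inhibition, read by MTT assay, with a stated time of 48 h, tested at 10 uM (on this read-out higher numbers stand for more inhibition of growth at the one concentration tested and lower numbers for less inhibition of growth), compound 3 `Cc1cc(=O)c2c(O)c(CN3CCCC3)c(O)c([C@H]3CCN(C)C[C@H]3O)c2o1` gives 22% while compound 2 `Cc1cc(=O)c2c(O)cc(OCc3ccco3)c([C@H]3CCN(C)C[C@H]3O)c2o1` gives 17% and compound 1 `Cc1cc(=O)c2c(O)cc(OCc3ccc(Br)cc3)c([C@H]3CCN(C)C[C@H]3O)c2o1` gives 13% on the same read-out. These numbers all lie within the scatter of one another, so compound 3 cannot be ranked against the other two and sits in the same band.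

The next compound to be tested is compound 4 `CCOC(=O)N1CCN(Cc2c(O)c([C@H]3CCN(C)C[C@H]3O)c3oc(C)cc(=O)c3c2O)CC1`, which keeps the core of compound 3 and differs from it in one group: 4-(ethoxycarbonyl)piperazin-1-yl in place of pyrrolidin-1-yl on a saturated chain carbon bound to an aromatic carbon is the whole change. In short, 4-(ethoxycarbonyl)piperazin-1-yl stands in place of pyrrolidin-1-yl on a saturated chain carbon bound to an aromatic carbon.

Among the measured compounds shown here, no measured step involves this place. For the measured compounds named here, the only measured step is a number 4 percentage points higher from compound 1 to compound 2 (within the scatter) and it lies elsewhere, on a saturated chain carbon bound to an oxygen on an aromatic ring. It therefore offers only weak guidance, though it shows one group exchange on this core that moved the number no further than the scatter. No step beyond the scatter is expected, and the expected change is a number 2 percentage points lower from compound 3 to compound 4 (within the scatter) with considerable uncertainty. For compound 4 the estimated value is 20% with an expected range from 6% to 36% in this assay once it is measured.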

Compound 4, percent growth inhibition at one concentration: 18%
For compound 4 the middle estimate is 2 percentage points above the measured one; the range from low to high includes it.
By their numbers in this assay, from the lowest: compounds 1, 2, 4 and 3 (each within the scatter of the next).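

This is the only step shown at this place, on a saturated chain carbon bound to an aromatic carbon, and in this assay putting 4-(ethoxycarbonyl)piperazin-1-yl in place of pyrrolidin-1-yl gives a number 4 percentage points lower from compound 3 to compound 4 (within the scatter). The entering group is far bigger, with 11 heavy atoms against 5, a six-membered ring instead of a five-membered one and 3 hydrogen-bond acceptors against 1, yet the number stays within the scatter, so this large exchange at this place does not separate the two compounds on this read-out. Nothing measured here explains this result.

The compounds shown leave open whether any group at this place can take the number beyond the scatter, for instance a morpholine ring, a primary amine or a carboxylic acid on the same chain carbon. They also leave open whether the ethoxycarbonyl part counts on its own, which a piperazine ring carrying only a methyl group in its place would separate from the change of ring.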